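The source may report more compounds than this note shows. Statements on the series, on what has been measured and on what is new or still open speak of the compounds shown alone.

Measured so far:
compound 1, `Cc1n[nH]c(N)c1-c1ccc(Cl)cc1`: an assay on Sf9 cells for inhibition of mitogen-activated protein kinase kinase kinase 14 (Homo sapiens), read by ADP-Glo, with a stated time of 60 min (on this read-out higher numbers stand for weaker inhibition and lower numbers for stronger inhibition), 61100 nM
compound 2, `Cc1nn(C(=O)C2CC2)c(N)c1-c1ccc(Cl)c(Cl)c1`: this assay 24300 nM
compound 3, `CC(=O)n1nc(C)c(-c2ccc(Cl)cc2)c1N`: this assay > 100000 nM

On the numbers shown compound 3 stands only as a limit of the assay, not a number (the limit of > 100000 nM in this assay, at which 1 of the 3 values shown sits). Among the measured compounds shown here, the one measured step touching the acyl group is an at least 1.6-fold higher number from compound 1 to compound 3 (0.21 log units; that floor lies within the scatter), acetyl in place of hydrogen on an aromatic nitrogen, with a floor within the scatter. Compound 4, `Cc1nn(C(=O)C2CC2)c(N)c1-c1ccc(Cl)cc1`, differs from compound 3 by cyclopropyl in place of methyl on a carbonyl carbon. For the measured compounds named here, no measured pair isolates this change; compound 2 carries the cyclopropylcarbonyl group and gives 24300 nM in this assay, but differs from compound 4 elsewhere too. In this assay compound 4 is therefore expected near 70000 nM (range 20000 nM to 250000 nM), an expected step of an at least 1.4-fold lower number from compound 3 to compound 4 (0.15 log units; that floor lies within the scatter), possibly still a limit.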

Compound 4, half-maximal inhibitory concentration: > 100000 nM
Compound 4 gave a limit, no number; the forecaster's own chance of this, stated with the estimate: 40%; at least 1.4-fold (0.15 log units) between middle value and limit.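

In this assay the change from acetyl to cyclopropylcarbonyl cannot be read, as compound 3 and compound 4 both stand as limits: the limit of > 100000 nM in this assay, at which 2 of the 4 values shown sit.

Hydrogen in place of chloro on an aromatic carbon gives an at least 4.1-fold higher number from compound 2 to compound 4 (0.61 log units; beyond the scatter), so the readable value of compound 2 depends on that chloro and not on the cyclopropylcarbonyl group alone. Putting the cyclopropylcarbonyl group on the shared core gives an at least 1.6-fold higher number from compound 1 to compound 4 (0.21 log units; that floor lies within the scatter), which shows no gain over compound 1.

Still open, going by these compounds, are what the second chloro does without an acyl group, and whether a longer chain or an amine on the carbonyl carbon gives a readable number.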